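The compounds below may be only part of what the source reports. "The series", "measured", "known", "first", "only" and "open" are said of these compounds alone.

Compound 1 `CSc1nccc(N2CCC(N(C)Cc3ccccc3Cl)CC2)n1` has the highest of the three numbers measured in a functional assay on BT-474 cells (Homo sapiens) for inhibition, read by luminescence, with a stated time of 72 h (on this read-out higher numbers stand for weaker inhibition and lower numbers for stronger inhibition), giving 1990 nM, though its gaps to the other two stay within the scatter. Compound 2 `CSc1nccc(N2CCC(N(C)Cc3ccc(Cl)cc3Cl)CC2)n1` gives 1620 nM, and compound 3 `CSc1nccc(N2CCC(N(C)Cc3ccc(C#N)cc3)CC2)n1` gives 1410 nM. The steps of a 1.2-fold lower number from compound 1 to compound 2 (0.09 log units; within the scatter), a 1.4-fold lower number from compound 1 to compound 3 (0.15 log units; within the scatter) and a 1.1-fold lower number from compound 2 to compound 3 (0.06 log units; within the scatter) were all small. Compound 4 `CSc1nccc(N2CCC(N(C)Cc3c(Cl)cccc3Cl)CC2)n1` differs from compound 1 by chloro in place of hydrogen on an aromatic carbon. Among the compounds with values here, the closest precedent is the step from compound 1 to compound 2, which also added a chloro group to the same aromatic ring and barely moved the number. For compound 4 the expected step is therefore a 1.0-fold lower number from compound 1 to compound 4 (0.02 log units; within the scatter), nothing beyond the scatter. Compound 4 is estimated at 1900 nM, with a range from 900 nM to 4000 nM.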

Compound 4, half-maximal inhibitory concentration: 780 nM
Beside the measured number, compound 4's estimate is 2.4-fold (0.39 log units) above it; the measured number lies below the stated range.
By their numbers in this assay, from the lowest: compounds 4, 3, 2 and 1 (each within the scatter of the next, the first and the last beyond it).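

In this assay, the place of the second chloro group counts: the change to 2,6-dichlorophenyl is a step beyond the scatter (a 2.6-fold lower number from compound 1 to compound 4 (0.41 log units; beyond the scatter)), whereas the chloro group added in compound 2 was not. Changing 2,4-dichlorophenyl to 2,6-dichlorophenyl also matters (a 2.1-fold lower number from compound 2 to compound 4 (0.32 log units; beyond the scatter)), while the comparison with the nitrile stays within the scatter (a 1.8-fold lower number from compound 3 to compound 4 (0.26 log units; within the scatter)), so compound 4 cannot be ranked apart from compound 3. Nothing available explains why this chloro group makes a difference.

On these data alone, whether the gain needs chlorine at all remains open, since 2,6-dimethylphenyl or 2,6-dimethoxyphenyl could show whether other groups do the same.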